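The source may report more compounds than this note shows. Statements on the series, on what has been measured and on what is new or still open speak of the compounds shown alone.

Measured compounds in a functional assay on CHO cells for positive allosteric modulation of metabotropic glutamate receptor 2 (Homo sapiens), read by scintillation counting and GTPgammaS binding, with a stated time of 30 min; a lower number here means a smaller maximal response, a higher number a larger maximal response:
compound 1, `CC(C)CCn1ccc(-c2ccc(Oc3ccncc3)cc2)c(C#N)c1=O`: 245%
compound 2, `CNc1ccc(-c2ccn(CCC(C)C)c(=O)c2C#N)cc1`: 186%

Within the data shown here, compound 2 stands lowest of the two numbers; its only neighbour is compound 1, and the gap between them is a number 59 percentage points lower from compound 1 to compound 2 (beyond the scatter), the step in which methylamino replaces (pyridin-4-yl)oxy on an aromatic carbon.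

Compound 3, `Cc1ncccc1Oc1ccc(-c2ccn(CCC(C)C)c(=O)c2C#N)cc1`, is not yet measured. Its change from compound 2:
(2-methylpyridin-3-yl)oxy in place of methylamino on an aromatic carbon

Among the measured compounds shown here, the one measured step that bears on this is a number 59 percentage points lower from compound 1 to compound 2 (beyond the scatter): removing an oxygen-linked six-membered aromatic ring with one hetero atom in favour of methylamino lowered the maximal response well beyond the scatter. Compound 3 reverses that kind of change, putting (2-methylpyridin-3-yl)oxy in place of methylamino. For the measured compounds named here, the added methyl and the changed point of attachment of the ring are covered by no measured pair, so the size of the return is uncertain, but the direction expected is upward, of a size in the same range. The estimate for compound 3 is 230%, with a range of 185% to 275%, meaning an expected step of a number 44 percentage points higher from compound 2 to compound 3 (beyond the scatter).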

Compound 3, largest response reached (Emax), in percent of the reference or control that the assay uses: 256%
Beside the measured number, compound 3's estimate is 26 percentage points below it, and the stated range covers the measured number.
By their numbers in this assay, from the lowest: compound 2; then compound 1; then compound 3.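

In this assay, the (2-methylpyridin-3-yl)oxy group, on the aromatic carbon para to a large group, gives a number 70 percentage points higher from compound 2 to compound 3 (beyond the scatter) in a large step, so the maximal response lost with methylamino is regained with a second oxygen-linked ring and does not depend on the pyridin-4-yl ring alone. The attached ring can also be altered without loss: the change to 2-methylpyridin-3-yl on the oxygen gives a number 11 percentage points higher from compound 1 to compound 3 (beyond the scatter) in a modest step that is still beyond the scatter. No available evidence explains either step.

The methyl group and the moved point of attachment arrive together in this single comparison, so their separate contributions cannot be read from these compounds. Still open, going by these compounds, is how a plain phenoxy group, with no ring nitrogen, or a pyridin-3-yloxy group without the methyl would behave at this position, and whether a larger group on the ring, such as a methoxy or a second methyl, would hold the maximal response.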